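A few compounds are considered here, and "the series" means these few. Any claim that something is new, unique, unknown or untested is made for them only; others in the source may bear on it.

Of the compounds shown here, two have been measured so far. In a functional assay on A549 cells (Homo sapiens) for inhibition, read by sulforhodamine B assay, with a stated time of 48 h (on this read-out higher numbers stand for weaker inhibition of growth and lower numbers for stronger inhibition of growth), compound 1 `COC(=O)[C@@]1(C)CCC=C2[C@@H]1CC[C@@H](C)[C@]2(C)Cc1c[nH]c2ccc(C(F)(F)F)cc12` gives 15000 nM, while compound 2 `COC(=O)[C@@]1(C)CCC=C2[C@@H]1CC[C@@H](C)[C@]2(C)Cc1c[nH]c2c(C)cccc12` gives 11000 nM. Compound 2 stands at the lowest of the two numbers shown, but compound 1 sits within the scatter of it, so the two are not separated. Compound 3 `COC(=O)[C@@]1(C)CCC=C2[C@@H]1CC[C@@H](C)[C@]2(C)Cc1c[nH]c2c(Cl)cccc12` differs from compound 2 by chloro in place of methyl on an aromatic carbon. Among the measured compounds shown here, no step between measured compounds weighs such a change, so in this assay no step beyond the scatter is expected, in either direction. Compound 3 is therefore estimated at 10000 nM, with a range from 4000 nM to 25000 nM. The expected step is a 1.1-fold lower number from compound 2 to compound 3 (0.04 log units; within the scatter).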

Compound 3, concentration for 50% growth inhibition: 22000 nM
The estimate for compound 3 lay 2.2-fold (0.34 log units) below the measured number, within the range that was stated.
By their numbers in this assay, from the lowest: compounds 2, 1 and 3 (each within the scatter of the next).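

In this assay, chloro in place of methyl on this aromatic carbon, ortho to a fused ring and meta to a fused ring, gives a 2.0-fold higher number from compound 2 to compound 3 (0.30 log units; within the scatter) as the first step read at this position. The exchange of these two groups therefore leaves the pair unseparated, so the methyl is not shown to be needed here. No measurement on hand bears on this result. Going by these compounds, whether an amine, a carboxylic acid or a longer chain on this carbon would move the number beyond the scatter stays open. So does the same exchange at other carbons of the ring.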